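From Hydroxy to Chloro on Compound 2

The source may report more compounds than this note shows. Statements on the series, on what has been measured and on what is new or still open speak of the compounds shown alone.

In a functional assay on A2780 cells (Homo sapiens) for antiproliferative activity, read by MTT assay, with a stated time of 48 h (on this read-out higher numbers stand for weaker inhibition of growth and lower numbers for stronger inhibition of growth), compound 1 `COC(=O)N1N=C(c2ccccc2)CC1c1cc(OC)c(OC)c(OC)c1` gives 2770 nM and compound 2 `COC(=O)N1N=C(c2cccc(O)c2)CC1c1cc(OC)c(OC)c(OC)c1` gives 810 nM, the lower of the two numbers and so the stronger inhibition of growth. For the measured compounds named here, the only measured step is a 3.4-fold lower number from compound 1 to compound 2 (0.53 log units; beyond the scatter), and it comes with hydroxy in place of hydrogen on an aromatic carbon.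

Compound 3 `COC(=O)N1N=C(c2cccc(Cl)c2)CC1c1cc(OC)c(OC)c(OC)c1` keeps the shared core but carries chloro in place of hydroxy on an aromatic carbon, meta to a large group: chloro in place of hydroxy on an aromatic carbon. The hydroxy that accompanied the earlier drop is therefore gone, and part of that drop may be lost. Going by the values given here, no measured compound carries chloro, so the data cannot say how much, and a full return to the number of compound 1 is not assumed.

In this assay a small move toward a higher number is expected, with the estimated step being a 1.9-fold higher number from compound 2 to compound 3 (0.27 log units; within the scatter). For compound 3 the estimated value is 1500 nM, with an expected range from 550 nM to 4000 nM.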

Compound 3, concentration for 50% growth inhibition: 1540 nM
The estimate for compound 3 lay 1.0-fold (0.01 log units) below the measured number; low and high end bracket the measured number.
By their numbers in this assay, from the lowest: compounds 2, 3 and 1 (each within the scatter of the next, the first and the last beyond it).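

Putting chloro in place of the hydroxy gives a 1.9-fold higher number from compound 2 to compound 3 (0.28 log units; within the scatter), and chloro in place of hydrogen gives a 1.8-fold lower number from compound 1 to compound 3 (0.25 log units; within the scatter). Both steps lie within the scatter, although compound 1 and compound 2 differ beyond it, so this single result places compound 3 between two compounds without separating it clearly from either one, and it cannot show whether chloro keeps the gain seen with the hydroxy or loses it. The computed difference also counts 1 hydrogen-bond donor for hydroxy and 0 for chloro, yet no firm link between that count and growth inhibition can be drawn from these numbers, and no outside measurement is available to explain the result.

As far as these compounds go, what an amine or a carboxylic acid would do on this same aromatic carbon remains open, and such groups could help show whether the step seen with the hydroxy is specific to that group. For the compounds shown here, also open is whether the small steps seen with chloro would hold on a different core or in other cells, as only one chloro compound and one cell line appear here.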